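The source may report more compounds than this note shows. Statements on the series, on what has been measured and on what is new or still open speak of the compounds shown alone.

Compound 1, `CCCCCCCCOc1nc(N)nc2c1ncn2/C=C1/CC1(CO)CO`: in an ADME assay on BCBL1 cells (Homo sapiens) for cytotoxicity, with a stated time of 7 days (on this read-out lower numbers stand for higher toxicity in this test and higher numbers for lower toxicity in this test), compound 1 reaches only the limit of > 20000 nM.
Compound 2, `Nc1nc(N2CCCC2)c2ncn(/C=C3/CC3(CO)CO)c2n1`: in this assay compound 2 likewise gives only the limit of > 20000 nM.
Compound 3, `COCCOc1nc(N)nc2c1ncn2/C=C1/CC1(CO)CO`: in this assay compound 3 also gives only the limit of > 20000 nM.

Compound 3 therefore stands at the limit of this assay, and nothing more can be read from its number. The same holds for its two neighbours, as the limit of > 20000 nM in this assay, at which 3 of the 3 values shown sit, shows. The step that the two limits leave unreadable from compound 1 to compound 3 and the step that the two limits leave unreadable from compound 2 to compound 3 are both unreadable. Each ends at a limit on both sides, so neither tells how the tail beyond the aromatic oxygen matters for toxicity in this assay.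

The next compound, compound 4, `CCCCOc1nc(N)nc2c1ncn2/C=C1/CC1(CO)CO`, carries a single change from compound 3: ethyl in place of methoxy on a saturated chain carbon, two bonds along the chain from an oxygen on an aromatic ring. The measured steps that bear on it, from compound 1 and from compound 2 to compound 3, leave no readable size, so there is no ground to expect any step beyond the scatter in this assay, in either direction.

Compound 4 is accordingly expected to stay at the limit as well, with an estimated value of 30000 nM, in a range from 15000 nM to 100000 nM, and the estimated step that the limit leaves unreadable from compound 3 to compound 4 is expected to be unreadable in the same way.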

Compound 4, half-maximal cytotoxic concentration: > 20000 nM
Compound 4: only a limit was reported (the forecaster's own chance of this, stated with the estimate: 85%); the middle value does not contradict the limit.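

In this assay compound 4 gives only a limit, > 20000 nM. Its steps from compound 1, compound 2 and compound 3 therefore cannot be read, and no new step emerges, as all four compounds share one limit: the limit of > 20000 nM in this assay, at which 4 of the 4 values shown sit.

The compounds shown leave open whether the group on the aromatic carbon affects toxicity in this assay at all.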